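Compound 2: (trifluoromethyl)sulfanyl in place of chloro

The source may hold more compounds than are shown below. What is called first, only, known or untested is meant among the compounds shown, and "the series" means these compounds.

The three measured compounds share the core of compound 1 (`C=C(Br)C(=O)Nc1cccc(/C=C/C(=O)Nc2ccc(F)c(F)c2)c1`) and differ in the group on an amide-type nitrogen. In a functional assay on SEM cells (Homo sapiens) for inhibition, read by MTT assay, with a stated time of 72 h (a higher number here means a weaker inhibitor, a lower number a stronger inhibitor), compound 1 gives 90 nM as the lowest number. Compound 2 (`C=C(Br)C(=O)Nc1cccc(/C=C/C(=O)Nc2ccc(Cl)cc2)c1`) gives 1190 nM and compound 3 (`C=C(Br)C(=O)Nc1cccc(/C=C/C(=O)NCc2ccc(C)cc2)c1`) gives 1300 nM so compound 2 stands level with compound 3 and well apart from compound 1.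

Compound 4 (`C=C(Br)C(=O)Nc1cccc(/C=C/C(=O)Nc2ccc(SC(F)(F)F)cc2)c1`) carries (trifluoromethyl)sulfanyl in place of chloro on an aromatic carbon. Among the compounds with values here, two measured steps bear on this. The step of a 13-fold higher number from compound 1 to compound 2 (1.12 log units; beyond the scatter) is large and shows that the 4-chlorophenyl and 3,4-difluorophenyl groups can differ widely. The step of a 1.1-fold higher number from compound 2 to compound 3 (0.04 log units; within the scatter) lies within the scatter. Neither step involves this exchange, so the data give no direction for it. The estimated step is a 1.2-fold lower number from compound 2 to compound 4 (0.08 log units; within the scatter) and is expected to stay within the scatter, with a wide margin on both sides. In this assay the estimate for compound 4 is 1000 nM (expected range 250 nM to 4000 nM).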

Compound 4, half-maximal inhibitory concentration: 12700 nM
Beside the measured number, compound 4's estimate is 13-fold (1.10 log units) below it; measured number above the stated range.
By their numbers in this assay, from the lowest: compound 1; then compounds 2 and 3 (each within the scatter of the next); then compound 4.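

In this assay, the aromatic carbon para to a large group does not tolerate every exchange: (trifluoromethyl)sulfanyl in place of chloro gives an 11-fold higher number from compound 2 to compound 4 (1.03 log units; beyond the scatter). The earlier steps shown here replaced the whole group on the amide-type nitrogen, whereas this one alters a single substituent on that group, so one substituent alone can produce a large step. The entering group has 5 heavy atoms against 1 and adds a hydrogen-bond acceptor, but no measurement available here ties the step to either difference or to any other cause.

Still open, from the compounds shown here alone, is how an amine, a carboxylic acid or a methoxy group would read at this place. Also open, going by these compounds, is whether the same exchange gives a step of similar size on the 4-methylbenzyl group of compound 3.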